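Butyl in Place of Isopropyl on the Core Nitrogen

The compounds below may be only part of what the source reports. "The series", "measured", "known", "first", "only" and "open" are said of these compounds alone.

Compound 1, `CC(C)n1c(=O)n(C(=O)NCCN2CCN(C)CC2)c2cc(F)ccc21`: in a functional assay for antagonist activity at 5-hydroxytryptamine receptor 4 (Cavia porcellus) (a lower number here means a less potent compound, a higher number a more potent compound, by a factor of ten per unit of this negative logarithm), compound 1 gives 6.88.
Compound 2, `CC(C)n1c(=O)n(C(=O)NCCN2CCN(C)CC2)c2ccccc21`: in this assay compound 2 gives only a limit of the assay, < 6.
Compound 3, `CC(C)n1c(=O)n(C(=O)NCCCN2CCN(C)CC2)c2ccccc21`: in this assay compound 3 likewise gives only a limit of the assay, < 6.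

Compound 2 therefore stands at the floor of what this assay reports, at the limit of < 6 in this assay, at which 2 of the 3 values shown sit, and only compound 1 supplies a number. The step from compound 1 to compound 2, hydrogen in place of fluoro on an aromatic carbon, is a number at least 0.88 log units lower from compound 1 to compound 2 (beyond the scatter). The step from compound 2 to compound 3, on the saturated chain, is a step that the two limits leave unreadable from compound 2 to compound 3.

Compound 4, `CCCCn1c(=O)n(C(=O)NCCN2CCN(C)CC2)c2ccccc21`, differs from compound 2 by butyl in place of isopropyl on an aromatic nitrogen. Neither measured step touches the group on the aromatic nitrogen: compounds 1, 2 and 3 all carry isopropyl there. The measured steps thus give no guide to the direction or size of this change, and since compound 2 itself sits at a limit, the most likely outcome is that compound 4 is again reported as a limit. Compound 4 is expected at about 5.7, within 5 to 6.5. This estimate corresponds to an expected step that the limit leaves unreadable from compound 2 to compound 4.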

Compound 4, negative logarithm of the antagonist equilibrium constant: < 6
Compound 4 was reported as a limit (the forecaster's own chance of this, stated with the estimate: 65%); the middle value lies beyond the limit too.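

In this assay compound 4 gives only a limit of the assay, < 6. Compound 2 stands at the same limit, so no step can be read between compound 2 and compound 4: the limit of < 6 in this assay, at which 3 of the 4 values shown sit. The compounds shown leave open whether butyl or isopropyl on the aromatic nitrogen gives the higher number.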